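This account rests on a few compounds, and the source may have more. Where it says the series, first, only, none or still open, it means among the compounds named here.

Compound 1 `CCCNC(=O)Nc1nc2ccc(-c3cnc(OC)c(NS(=O)(=O)c4ccc(F)cc4)c3)cn2n1` gives 360 nM in a functional assay on MCF7 cells (Homo sapiens) for cytotoxicity, read by MTT assay, with a stated time of 72 h; a lower number here means a stronger inhibitor, a higher number a weaker inhibitor.
Compound 2 `COc1ncc(-c2ccc3nc(NC(=O)NC4CC4)nn3c2)cc1NS(=O)(=O)c1ccc(F)cc1` gives 300 nM in this assay.
Compound 3 `CCN(CC)CCNC(=O)Nc1nc2ccc(-c3cnc(OC)c(NS(=O)(=O)c4ccc(F)cc4F)c3)cn2n1` gives 740 nM in this assay.

Among these three, compound 2 shows the lowest number, although compound 1 sits so close that the two cannot be separated; compound 3 stands clearly apart with the highest number. Compound 4 `COc1ncc(-c2ccc3nc(NC(=O)NCCN4CCCCC4)nn3c2)cc1NS(=O)(=O)c1ccc(F)cc1` has not yet been measured. It differs from compound 2 at the urea end: 2-(piperidin-1-yl)ethyl in place of cyclopropyl on an amide-type nitrogen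

For the measured compounds named here, only one measured step changes a single place, and it is a 1.2-fold lower number from compound 1 to compound 2 (0.08 log units; within the scatter); it says that swapping one small carbon group for another on the amide-type nitrogen does almost nothing. Going by the values given here, compound 3 is the one compound that carries a longer chain on that nitrogen, and its number is the highest of the three, but compound 3 also differs from compound 2 on the sulfonyl side, so its higher number can only be a hint, not a measured step. On that hint the expectation for compound 4 is a moderate rise rather than no change: a 1.8-fold higher number from compound 2 to compound 4 (0.26 log units; within the scatter) is the step expected. The estimate for compound 4 is therefore 550 nM, expected to fall between 250 nM and 1200 nM.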

Compound 4, half-maximal inhibitory concentration: 200 nM
For compound 4 the middle estimate is 2.8-fold (0.44 log units) above the measured one, and the stated range ends above it.
By their numbers in this assay, from the lowest: compounds 4, 2 and 1 (each within the scatter of the next); then compound 3.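

Until now, this nitrogen had only been shown to accept one small carbon group in place of another. Compound 4 extends that picture to a much larger group: in this assay, replacing cyclopropyl, with 3 heavy atoms, by 2-(piperidin-1-yl)ethyl, with 8 heavy atoms including a ring nitrogen, gives a 1.5-fold lower number from compound 2 to compound 4 (0.18 log units; within the scatter), and the comparison with the propyl compound gives a 1.8-fold lower number from compound 1 to compound 4 (0.26 log units; within the scatter), so neither step separates the compounds, and this end of the urea accepts a considerably bigger substituent with a nitrogen-containing ring without a measurable loss in this cell assay. Nothing available here explains why the number stays put at this position.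

From the compounds shown here alone, it remains open whether this tolerance extends to a morpholine ring in place of the piperidine, to a longer chain between the urea and the ring, or to a carboxylic acid at the end of the chain. Compound 3 differs from the others both on this nitrogen and on the sulfonyl side, so the compounds shown do not reveal which of those two changes goes with its number.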